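This account rests on a few compounds, and the source may have more. Where it says the series, first, only, none or still open, it means among the compounds named here.

Compound 1 `CCCCOc1ccc(C(=O)/C=C/c2c(/C=C/c3ccc(OC)cc3)cc(OC)cc2OC)cc1` is one of three compounds sharing a core in which the ketone-bearing aromatic ring carries a single substituent. In a functional assay on A549 cells (Homo sapiens) for antiproliferative activity, read by MTT assay, with a stated time of 48 h (on this read-out higher numbers stand for weaker inhibition and lower numbers for stronger inhibition), compound 1 gives 8.7 ug/mL, the highest of the three numbers, although none of the three stands apart from the others beyond the scatter. Compound 2 `COc1ccc(/C=C/c2cc(OC)cc(OC)c2/C=C/C(=O)c2ccc(C(F)(F)F)cc2)cc1` gives 7.8 ug/mL in this assay, and compound 3 `COc1ccc(/C=C/c2cc(OC)cc(OC)c2/C=C/C(=O)c2ccc(-c3ccccc3)cc2)cc1` gives 4.6 ug/mL. The three steps between them are small: a 1.1-fold lower number from compound 1 to compound 2 (0.05 log units; within the scatter), a 1.9-fold lower number from compound 1 to compound 3 (0.28 log units; within the scatter) and a 1.7-fold lower number from compound 2 to compound 3 (0.23 log units; within the scatter), each within the scatter.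

Compound 4 `CCN(CC)c1ccc(C(=O)/C=C/c2c(/C=C/c3ccc(OC)cc3)cc(OC)cc2OC)cc1` differs from compound 1 in the same position that the three measured compounds vary: diethylamino in place of butoxy on an aromatic carbon. All three measured steps exchange the substituent at this one site, and none of them moved the number beyond the scatter. On that basis, no step beyond the scatter is expected for compound 4 in this assay either, in neither direction, and the exchange of butoxy for diethylamino is expected to leave compound 4 near the measured three. The estimate for compound 4 in this assay is therefore 7 ug/mL, with a range from 3.5 ug/mL to 14 ug/mL, which corresponds to an expected step of a 1.2-fold lower number from compound 1 to compound 4 (0.09 log units; within the scatter).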

Compound 4, half-maximal inhibitory concentration: 5.4 ug/mL
For compound 4 the middle estimate is 1.3-fold (0.11 log units) above the measured one; measured number inside the range.
By their numbers in this assay, from the lowest: compounds 3, 4, 2 and 1 (each within the scatter of the next).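

In this assay the diethylamino group of compound 4 does not stand apart from the three groups already seen at this site, with a 1.6-fold lower number from compound 1 to compound 4 (0.21 log units; within the scatter) and a 1.4-fold lower number from compound 2 to compound 4 (0.16 log units; within the scatter) and a 1.2-fold higher number from compound 3 to compound 4 (0.07 log units; within the scatter) as its steps. Diethylamino is the first group shown here that carries nitrogen, and this site has now held butoxy, trifluoromethyl, phenyl and diethylamino with no step among the four compounds beyond the scatter. The exchange of butoxy for diethylamino keeps the heavy-atom count and the hydrogen-bond donor and acceptor counts unchanged, and nothing measured here offers an explanation for the values of these four compounds.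

The compounds shown leave open whether a primary amine, a carboxylic acid or a longer alkoxy chain at this site would produce a step beyond the scatter, so the limits of this tolerance remain unknown. They also leave open whether changes elsewhere on the shared core, such as replacing the methoxy groups or the ketone, would matter more than changes at this site.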